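This account rests on a few compounds, and the source may have more. Where it says the series, first, only, none or still open, it means among the compounds named here.

Working notes on three aryl variants of one shared core, read in a functional assay on KBVIN cells (Homo sapiens) for antiproliferative activity, read by sulforhodamine B assay, with a stated time of 3 days; a higher number here means that more compound is needed for the effect, a lower number that less compound is needed. Compound 1 `CCC1=C(O)c2c(oc(-c3ccc(C)c(F)c3)cc2=O)C(CC)(CC)C1=O` gives 2.95 uM, compound 2 `CCC1=C(O)c2c(oc(-c3cc(C)c(C)cc3C)cc2=O)C(CC)(CC)C1=O` gives 4.37 uM and compound 3 `CCC1=C(O)c2c(oc(-c3ccc(OC)cc3C)cc2=O)C(CC)(CC)C1=O` gives 2.62 uM. Compound 3 therefore stands within the scatter of both other compounds, with a 1.1-fold lower number from compound 1 to compound 3 (0.05 log units; within the scatter) and a 1.7-fold lower number from compound 2 to compound 3 (0.22 log units; within the scatter).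

The next compound to be read is compound 4 `CCC1=C(O)c2c(oc(-c3ccc(O)c(C)c3C)cc2=O)C(CC)(CC)C1=O`. It carries 4-hydroxy-2,3-dimethylphenyl in place of 4-methoxy-2-methylphenyl on an aromatic carbon next to the ring oxygen (4-hydroxy-2,3-dimethylphenyl in place of 4-methoxy-2-methylphenyl on an aromatic carbon). The measured steps that bear on this change are the aryl exchanges at that same carbon: the two above and a 1.5-fold higher number from compound 1 to compound 2 (0.17 log units; within the scatter). All three lie within the scatter, so the aryl groups measured so far are not separated in this assay. Within the data shown here, none of the measured compounds has a hydroxy group on this aryl ring, so the data do not cover that feature and the range is kept wide. No step beyond the scatter is expected in this assay, and neither direction is favoured. The estimated step is a 1.1-fold higher number from compound 3 to compound 4 (0.06 log units; within the scatter). For compound 4 the estimated value is 3 uM, with an expected range of 1.3 uM to 7 uM.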

Compound 4, concentration for half-maximal effect: 2.75 uM
For compound 4 the middle estimate is 1.1-fold (0.04 log units) above the measured one; low and high end bracket the measured number.
By their numbers in this assay, from the lowest: compounds 3, 4, 1 and 2 (each within the scatter of the next).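

Among these compounds, compound 4 is the first with a hydroxy group on this aryl ring, and in this assay the new group stays within the scatter of all three earlier aryl groups (a 1.0-fold higher number from compound 3 to compound 4 (0.02 log units; within the scatter); a 1.1-fold lower number from compound 1 to compound 4 (0.03 log units; within the scatter); a 1.6-fold lower number from compound 2 to compound 4 (0.20 log units; within the scatter)). At this aromatic carbon next to the ring oxygen, the series can therefore carry a hydrogen-bond donor on the aryl ring, as in 4-hydroxy-2,3-dimethylphenyl, with no step beyond the scatter, so the flat picture from the three earlier compounds now extends to a fourth aryl group. No measurement is available that would explain this flat picture.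

From the compounds shown here alone, the exchange from 4-methoxy-2-methylphenyl to 4-hydroxy-2,3-dimethylphenyl alters both the oxygen substituent and the methyl pattern, so the separate contribution of the hydroxy group and of the added ring methyl remains open. Also open, going by these compounds, is whether any group at this carbon steps beyond the scatter in this assay, for example an aryl ring bearing an amine or a carboxylic acid, or a longer chain such as butoxy in place of methoxy.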